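Phenoxy in place of propyl on the chain

The source may report more compounds than this note shows. Statements on the series, on what has been measured and on what is new or still open speak of the compounds shown alone.

In a functional assay on HCT-116 cells (Homo sapiens) for antiproliferative activity, read by MTT assay, with a stated time of 48 h (a lower number here means a stronger inhibitor of growth, a higher number a weaker inhibitor of growth), compound 1 `Cc1ccc(-c2cnc(N(CCCCOc3ccccc3)Cc3ccc(C(=O)NO)cc3)s2)cc1` gives 680 nM, compound 2 `CCCCN(Cc1ccc(C(=O)NO)cc1)c1ncc(-c2ccc(C)cc2)s1` gives 8780 nM and compound 3 `CCCCCCN(Cc1ccc(C(=O)NO)cc1)c1ncc(-c2ccc(C)cc2)s1` gives 4850 nM. Compound 3 stands level with compound 2, since the data show a 1.8-fold lower number from compound 2 to compound 3 (0.26 log units; within the scatter), and the gap to compound 1 is clear, at a 7.1-fold higher number from compound 1 to compound 3 (0.85 log units; beyond the scatter).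

Compound 4 `Cc1ccc(-c2cnc(N(CCCOc3ccccc3)Cc3ccc(C(=O)NO)cc3)s2)cc1` carries phenoxy in place of propyl on a saturated chain carbon, three bonds along the chain from a nitrogen on an aromatic ring. The nearest precedents are the two phenoxy steps at four bonds along the chain, a 7.1-fold higher number from compound 1 to compound 3 (0.85 log units; beyond the scatter) read in reverse and a 13-fold higher number from compound 1 to compound 2 (1.11 log units; beyond the scatter). Among the measured compounds shown here, no measured compound shows what moving the phenoxy one bond closer does. A step of similar direction and modest size is therefore expected in this assay, resting on compound 1 at 680 nM. The expected step is a 5.4-fold lower number from compound 3 to compound 4 (0.73 log units; beyond the scatter). For compound 4 the estimated value is 900 nM, with an expected range of 350 nM to 2400 nM.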

Compound 4, concentration for 50% growth inhibition: 4140 nM
For compound 4 the middle estimate is 4.6-fold (0.66 log units) below the measured one, and the stated range ends below it.
By their numbers in this assay, from the lowest: compound 1; then compounds 4, 3 and 2 (each within the scatter of the next, the first and the last beyond it).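

In this assay, the phenoxy group does not keep its advantage when its chain is shortened, with a 6.1-fold higher number from compound 1 to compound 4 (0.78 log units; beyond the scatter) (the chain length carrying the phenoxy group therefore counts in this series, at least across these two compounds). At three bonds along the chain, phenoxy in place of propyl gives no readable change, with a 1.2-fold lower number from compound 3 to compound 4 (0.07 log units; within the scatter), while phenoxy in place of methyl gives only a modest step, with a 2.1-fold lower number from compound 2 to compound 4 (0.33 log units; beyond the scatter), so the phenoxy group at this position adds little over the plain alkyl chains. Nothing measured here speaks to why the chain length has this effect.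

Going by these compounds, whether a longer chain ending in phenoxy would keep or extend the level of compound 1 remains open. So does whether an amine or a carboxylic acid at the chain end could take the place of the phenoxy group.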